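This account rests on a few compounds, and the source may have more. Where it says the series, first, only, none or still open, it means among the compounds named here.

Compound 3 `COc1ccc(N/C=C\C(=O)c2nc(-c3ccc(OC)cc3)n3ccccc23)cc1` stands among three compounds measured in a functional assay on MDA-MB-231 cells (Homo sapiens) for cytotoxicity, read by MTT assay, with a stated time of 48 h; on this read-out lower numbers stand for stronger inhibition and higher numbers for weaker inhibition. For compound 3 the read-out is only the limit > 30000 nM. Compound 2 `COc1ccc(-c2nc(C(=O)/C=C\Nc3ccc(Cl)cc3)c3ccccn23)cc1` carries chloro where compound 3 carries methoxy. In this assay compound 2 likewise gives only the limit > 30000 nM. Compound 1 `O=C(/C=C\Nc1ccc(F)cc1)c1nc(-c2ccc(F)cc2)n2ccccc12` gives a number, 25100 nM. Going by the values given here, the one single-point step within this set, a step that the two limits leave unreadable from compound 2 to compound 3, cannot be sized, because both of its ends sit at the limit of > 30000 nM in this assay, at which 2 of the 3 values shown sit. Compound 4 `COc1ccc(-c2nc(C(=O)/C=C\Nc3ccc(F)cc3)c3ccccn23)cc1` is reached from compound 3 by fluoro in place of methoxy on an aromatic carbon. Among the compounds with values here, no measured step isolates this exchange on the (4-fluorophenyl)amino side; the step from compound 2 to compound 3 concerns the same ring but a chloro-to-methoxy swap and is unreadable. The guidance is therefore weak: compound 1, which also bears a (4-fluorophenyl)amino group, sits close to the limit, while compound 2 and compound 3 rest at it. Compound 4 is expected to show no change beyond the scatter in this assay, so that a number no higher from compound 3 to compound 4 (the limit leaves the size open) is expected to be essentially flat. The estimate for compound 4 is 30000 nM, within 15000 nM to 60000 nM, with a fair chance that only a limit is returned.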

Compound 4, half-maximal inhibitory concentration: > 30000 nM
Compound 4 was reported as a limit; the forecaster's own chance of this, stated with the estimate: 60%; the middle value lies on the limit itself.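

Fluoro in place of methoxy or chloro on the anilino ring leaves compound 4 at a limit of the assay in this assay, so the steps among compound 2, compound 3 and compound 4 cannot be read, and none of these exchanges at this position can be given a size: the limit of > 30000 nM in this assay, at which 3 of the 4 values shown sit. The one step that can be read is an at least 1.1-fold higher number from compound 1 to compound 4 (0.07 log units; that floor lies within the scatter), where 4-fluorophenyl on the shared core gives way to 4-methoxyphenyl while the (4-fluorophenyl)amino group stays in place. Going by these compounds alone, this step is the first to isolate that other aromatic group, but its floor shows no change beyond the scatter, and the limit leaves open how large the true step is.

The compounds shown leave open whether any group at this position can bring the read-out down to a number well clear of the limit, for instance an amine such as dimethylamino or a carboxylic acid. They also leave open whether the (4-fluorophenyl)amino group matters at all when the 4-fluorophenyl group on the core is held fixed.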